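The source may hold more compounds than are shown below. What is called first, only, known or untested is meant among the compounds shown, and "the series" means these compounds.

In a functional assay on HCT-116 cells (Homo sapiens) for antiproliferative activity, read by sulforhodamine B assay, with a stated time of 72 h (on this read-out lower numbers stand for stronger inhibition and higher numbers for weaker inhibition), three compounds with a shared core differ in one group, on a saturated chain carbon bound to a saturated ring carbon. Compound 1 (`Cn1ncc(Cl)c1-c1cc(C(=O)N[C@@H]2CN[C@H](CC(O)CO)C[C@H]2c2ccc(Cl)c(Cl)c2)oc1Cl`) gives 1110 nM, compound 2 (`Cn1ncc(Cl)c1-c1cc(C(=O)N[C@@H]2CN[C@H](CC(=O)O)C[C@H]2c2ccc(Cl)c(Cl)c2)oc1Cl`) gives 4020 nM, and compound 3 (`C=CC[C@@H]1C[C@@H](c2ccc(Cl)c(Cl)c2)[C@H](NC(=O)c2cc(-c3c(Cl)cnn3C)c(Cl)o2)CN1`) gives 780 nM. The step of a 1.4-fold lower number from compound 1 to compound 3 (0.15 log units; within the scatter) stays within the scatter, whereas a 5.2-fold lower number from compound 2 to compound 3 (0.71 log units; beyond the scatter) goes beyond it, so compound 3 shares the low end of these numbers with compound 1. Compound 4 (`Cn1ncc(Cl)c1-c1cc(C(=O)N[C@@H]2CN[C@H](CCN3CCCC3)C[C@H]2c2ccc(Cl)c(Cl)c2)oc1Cl`) carries (pyrrolidin-1-yl)methyl in place of vinyl on a saturated chain carbon bound to a saturated ring carbon. For the measured compounds named here, the largest change at this place so far is that modest step, and a 3.6-fold higher number from compound 1 to compound 2 (0.56 log units; beyond the scatter) is also modest. Going by the values given here, none of the measured groups contains a five-membered non-aromatic ring, so the guide is loose, and no step beyond the scatter is expected in this assay. Compound 4 is estimated at 700 nM, with an expected range of 250 nM to 2000 nM. This estimate means an expected 1.1-fold lower number from compound 3 to compound 4 (0.05 log units; within the scatter).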

Compound 4, half-maximal inhibitory concentration: 1940 nM
Compound 4: the middle estimate sits 2.8-fold (0.44 log units) below what was measured, within the range that was stated.
By their numbers in this assay, from the lowest: compounds 3, 1 and 4 (each within the scatter of the next, the first and the last beyond it); then compound 2.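

At this place, on a saturated chain carbon bound to a saturated ring carbon, a group with a five-membered non-aromatic ring and a nitrogen gives weaker inhibition than vinyl in this assay (a 2.5-fold higher number from compound 3 to compound 4 (0.40 log units; beyond the scatter)). The same group still gives stronger inhibition than carboxy (a 2.1-fold lower number from compound 2 to compound 4 (0.32 log units; beyond the scatter)), while it cannot be told apart from 1,2-dihydroxyethyl (a 1.7-fold higher number from compound 1 to compound 4 (0.24 log units; within the scatter)). Nothing measured here explains these steps. Still open, going by these compounds, is whether the ring or the nitrogen of (pyrrolidin-1-yl)methyl sets this number: a cyclopentyl group would carry the ring alone, a dimethylamino group the nitrogen alone.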